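Removing a trifluoromethyl group from an aryl ether thiosemicarbazide

This account rests on a few compounds, and the source may have more. Where it says the series, first, only, none or still open, it means among the compounds named here.

Of the compounds shown here, two have been tested so far: compound 1 `O=C(COc1ccc(Cl)c(Cl)c1)NNC(=S)NCc1ccc(-c2ccccc2)cc1` and compound 2 `O=C(COc1ccc(C(F)(F)F)cc1)NNC(=S)NCCCCC1CCCCC1`. In an assay on isolated protein for inhibition of A disintegrin and metalloproteinase with thrombospondin motifs 5 (Homo sapiens), read by spectrophotometry, with stated times of 10 min and 3 h (on this read-out higher numbers stand for weaker inhibition and lower numbers for stronger inhibition), compound 2 gives 540 nM, the lowest of the two numbers; compound 1 gives 1200 nM, a gap that lies beyond the usual scatter. Compound 3 `O=C(COc1ccccc1)NNC(=S)NCCCCC1CCCCC1` has not yet been measured. It differs from compound 2 by hydrogen in place of trifluoromethyl on an aromatic carbon. For the measured compounds named here, no measured pair shows this change, so the size of the step is unknown; a modest weakening, possibly within the scatter, is expected a 1.7-fold higher number from compound 2 to compound 3 (0.22 log units; within the scatter). Compound 3 is estimated at 900 nM, between 300 nM and 3000 nM.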

Compound 3, half-maximal inhibitory concentration: > 100000 nM
Compound 3 gave a limit, no number; the forecaster's own chance of this, stated with the estimate: 10%; middle value at least 110-fold (2.04 log units) away from the limit.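

In this assay, the trifluoromethyl group proves decisive, since putting hydrogen in its place gives an at least 180-fold higher number from compound 2 to compound 3 (2.26 log units; beyond the scatter). For compound 3, > 100000 nM is a limit of the assay and not a number. This single position, para to a large group, therefore carries much of the inhibition seen with compound 2, which could not be seen before, as compound 1 and compound 2 differ in more than one place.

The compounds shown leave open whether a methyl or methoxy group at this position would keep the inhibition, or whether trifluoromethyl alone does so.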